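Swapping a dimethoxy ring for an ethyl ring on a shared core

The compounds below may be only part of what the source reports. "The series", "measured", "known", "first", "only" and "open" are said of these compounds alone.

Compound 1 `CCc1ccc(Cn2c(CCc3ccccc3)nnc2[C@H](NC(=O)c2ccccn2)c2c[nH]c3ccccc23)cc1`: 67 nM
Compound 2 `COc1ccc(Cn2c(CCc3ccccc3)nnc2[C@H](NC(=O)c2ccncc2)c2c[nH]c3ccccc23)c(OC)c1`: 58 nM

Both compounds were tested in an in vitro assay on LLC-PK1 cells for displacement of a labelled ligand from growth hormone secretagogue receptor type 1 (Homo sapiens); on this read-out higher numbers stand for weaker inhibition and lower numbers for stronger inhibition. Compound 2 gives 58 nM, and compound 1 gives 67 nM; the two numbers lie within the scatter of each other, so neither stands apart. Compound 3 `CCc1ccc(Cn2c(CCc3ccccc3)nnc2[C@H](NC(=O)c2ccncc2)c2c[nH]c3ccccc23)cc1` is not yet measured. It differs from compound 2 by one change: 4-ethylphenyl in place of 2,4-dimethoxyphenyl on a saturated chain carbon bound to an aromatic nitrogen. Going by the values given here, no step between measured compounds is known for this change, so the expectation rests on the closeness of compound 1 and compound 2 alone. Compound 3 is expected to stay within the scatter of compound 2, a step of a 1.1-fold higher number from compound 2 to compound 3 (0.05 log units; within the scatter), giving an estimate of 65 nM with a range from 25 nM to 170 nM.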

Compound 3, half-maximal inhibitory concentration: > 1000 nM
Compound 3: no number, only a limit; the forecaster's own chance of this, stated with the estimate: 2%; middle value at least 15-fold (1.18 log units) from the limit.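

Compound 3 has only a limit, not a number: the limit of > 1000 nM in this assay, at which 1 of the 3 values shown sits.

Even so, the change at this position is far from neutral: with pyridin-4-yl on the carbonyl carbon, going from 2,4-dimethoxybenzyl to 4-ethylbenzyl gives an at least 17-fold higher number from compound 2 to compound 3 (1.23 log units; beyond the scatter). With 4-ethylbenzyl held fixed, the pyridine change also matters, giving an at least 14-fold higher number from compound 1 to compound 3 (1.17 log units; beyond the scatter).

The compounds shown leave open whether a benzyl group carrying a single methoxy, or a hydroxyl in place of the ethyl, would keep the inhibition seen with compound 2. From the compounds shown here alone, the true size of both steps also stays open.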